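The compounds below may be only part of what the source reports. "The series", "measured", "known", "first", "only" and "open" are said of these compounds alone.

Going by the values given here, in a functional assay on HCT-116 cells (Homo sapiens) for cytotoxicity, read by MTT assay, with a stated time of 48 h (on this read-out lower numbers stand for stronger inhibition and higher numbers for weaker inhibition), compound 2 `O=C(/C=C/c1ccc2c(c1)B(O)OC2)c1ccccc1F` gives 4200 nM, the lowest of the two numbers so far; compound 1 `O=C(/C=C/c1ccc2c(c1)B(O)OC2)c1ccc(O)cc1` gives 24100 nM, and a 5.7-fold lower number from compound 1 to compound 2 (0.76 log units; beyond the scatter) is the only measured step. Compound 3 `Cc1cccc(C(=O)/C=C/c2ccc3c(c2)B(O)OC3)c1` differs from compound 2 by 3-methylphenyl in place of 2-fluorophenyl on a carbonyl carbon. That one step bears only loosely on the new change, since both aryl groups in compound 3 and compound 2 carry no hydrogen-bond donor or acceptor, so little movement beyond the scatter is expected. Compound 3 is therefore estimated at 5000 nM, with a range from 1800 nM to 14000 nM, the expected step being a 1.2-fold higher number from compound 2 to compound 3 (0.08 log units; within the scatter).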

Compound 3, half-maximal inhibitory concentration: 6700 nM
Estimate against measurement, compound 3: 1.3-fold (0.13 log units) below; the measured number falls inside the stated range.
By their numbers in this assay, from the lowest: compounds 2 and 3 (each within the scatter of the next); then compound 1.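

In this assay, 3-methylphenyl in place of 2-fluorophenyl on the carbonyl carbon gives a 1.6-fold higher number from compound 2 to compound 3 (0.20 log units; within the scatter), so these two aryl groups cannot be told apart at this position. Set against 4-hydroxyphenyl, 3-methylphenyl gives a 3.6-fold lower number from compound 1 to compound 3 (0.56 log units; beyond the scatter), so two different aryl groups now stand apart from compound 1. No measured evidence bears on why these numbers fall as they do.

From the compounds shown here alone, what an amine or a carboxylic acid on this aryl group would do remains open, as does whether fluorine and methyl would match when compared on the same ring carbon.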